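The source may report more compounds than this note shows. Statements on the series, on what has been measured and on what is new or still open speak of the compounds shown alone.

Compound 1 `COc1cc2c(Oc3ccc(NC(=O)c4cn(-c5ccccc5OC)cn4)cc3F)ccnc2cc1OCCCN1CCN(C)CC1` gives 220 nM in a functional assay on MKN-45 cells (Homo sapiens) for cytotoxicity, read by MTT assay, with a stated time of 72 h; on this read-out lower numbers stand for stronger inhibition and higher numbers for weaker inhibition. Compound 2 `COc1cc2c(Oc3ccc(NC(=O)c4cn(-c5ccc(Cl)cc5)cn4)cc3F)ccnc2cc1OCCCN1CCN(C)CC1` gives 4110 nM. Compound 3 `COc1cc2c(Oc3ccc(NC(=O)c4cn(-c5ccc(Cl)cc5Cl)cn4)cc3F)ccnc2cc1OCCCN1CCN(C)CC1` gives 4840 nM.

Compound 1 stands lowest of the three: the step of a 19-fold higher number from compound 1 to compound 2 (1.27 log units; beyond the scatter) and the step of a 22-fold higher number from compound 1 to compound 3 (1.34 log units; beyond the scatter) are both large, whereas the step of a 1.2-fold higher number from compound 2 to compound 3 (0.07 log units; within the scatter) stays within the scatter. Compound 4 `COc1cc2c(Oc3ccc(NC(=O)c4cn(-c5ccccc5OC)cn4)cc3F)ccnc2cc1OCCCN1CCCCC1` differs from compound 1 by piperidin-1-yl in place of 4-methylpiperazin-1-yl on a saturated chain carbon, three bonds along the chain from an oxygen on an aromatic ring. Going by the values given here, none of the measured steps bears on this change; all three concern the aryl group on the aromatic nitrogen, and the chain end of the shared core is untouched among the measured compounds. Among the compounds with values here, with no measured step to draw on, a step of no more than the usual scatter is expected, a 1.4-fold higher number from compound 1 to compound 4 (0.13 log units; within the scatter). Compound 4 is therefore estimated at 300 nM, with a range from 100 nM to 900 nM.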

Compound 4, half-maximal inhibitory concentration: 260 nM
Beside the measured number, compound 4's estimate is 1.2-fold (0.06 log units) above it; the range from low to high includes it.
By their numbers in this assay, from the lowest: compounds 1 and 4 (each within the scatter of the next); then compounds 2 and 3 (each within the scatter of the next).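

Compound 1 and compound 4 carry the only difference at this position, and a 1.2-fold higher number from compound 1 to compound 4 (0.07 log units; within the scatter) in this assay shows that piperidin-1-yl can replace 4-methylpiperazin-1-yl on the chain without a step beyond the scatter. The ring nitrogen and hydrogen-bond acceptor that leave with 4-methylpiperazin-1-yl are thus not needed to hold the number in this series. Nothing measured here says why the two groups read alike.

On these data alone, whether morpholin-4-yl, a dimethylamino group or a shorter ethyl chain would read the same stays open. So does whether this exchange would hold with the 4-chlorophenyl group of compound 2.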